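Aryl variation at the chain carbon of the sulfonyl enones

This account rests on a few compounds, and the source may have more. Where it says the series, first, only, none or still open, it means among the compounds named here.

compound 1 `CC(=O)Oc1ccc(/C=C(\C(=O)c2ccc(Cl)cc2)S(=O)(=O)c2ccc(C)cc2)cc1` — 25000 nM
compound 2 `Cc1ccc(S(=O)(=O)/C(=C/c2sccc2C)C(=O)c2ccc(Cl)cc2)cc1` — 10000 nM
compound 3 `Cc1ccc(S(=O)(=O)/C(=C/c2ccc(Cl)cc2)C(=O)c2ccc(Cl)cc2)cc1` — 1000 nM

In a functional assay on DU-145 cells (Homo sapiens) for inhibition, read by trypan blue exclusion, with a stated time of 96 h (a lower number here means a stronger inhibitor of growth, a higher number a weaker inhibitor of growth), compound 3 gives 1000 nM, the lowest number of the three, with compound 2 giving 10000 nM and compound 1 giving 25000 nM. Compound 4 `Cc1ccc(S(=O)(=O)/C(=C/c2cc(C)cc(C)c2)C(=O)c2ccc(Cl)cc2)cc1` differs from compound 3 by 3,5-dimethylphenyl in place of 4-chlorophenyl on a double-bonded chain carbon bound to a double-bonded chain carbon. Two measured steps alter the group at that same place: a 25-fold lower number from compound 1 to compound 3 (1.40 log units; beyond the scatter) and a 10-fold lower number from compound 2 to compound 3 (1.00 log units; beyond the scatter). Among the compounds with values here, both show the 4-chlorophenyl of compound 3 as the most favourable group tried, and no measured step involves a dimethylphenyl, so the size of the new step is uncertain. A modest step towards a higher number a 3.0-fold higher number from compound 3 to compound 4 (0.48 log units; beyond the scatter) is expected. Compound 4 is estimated at 3000 nM, with a range of 800 nM to 15000 nM.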

Compound 4, concentration for 50% growth inhibition: 1000 nM
The estimate for compound 4 lay 3.0-fold (0.48 log units) above the measured number; low and high end bracket the measured number.
By their numbers in this assay, from the lowest: compounds 3 and 4 (each within the scatter of the next); then compound 2; then compound 1.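

In this assay, a chlorine on the phenyl at this chain carbon is not required: replacing 4-chlorophenyl with 3,5-dimethylphenyl gives no change at the digits printed from compound 3 to compound 4 (within the scatter). The dimethylphenyl also keeps the full margin over the other groups tried, with a 10-fold lower number from compound 2 to compound 4 (1.00 log units; beyond the scatter) and a 25-fold lower number from compound 1 to compound 4 (1.40 log units; beyond the scatter). No measured evidence accounts for this match between the two phenyl groups.

Still open, on these data alone, is whether a single methyl on the phenyl ring gives the same result as the two methyls of compound 4. As far as these compounds go, it is also open whether an amine or a carboxylic acid on that ring is tolerated.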